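Amide-side aryl replacement on a shared core

A few compounds are considered here, and "the series" means these few. Any claim that something is new, unique, unknown or untested is made for them only; others in the source may bear on it.

Compound 1 `O=C(Nc1ccc(Cl)c(-c2nnc3c(Cl)cccn23)c1)c1ccc(F)cc1Cl`: > 100000 nM in a functional assay on HeLa cells (Homo sapiens) for antiproliferative activity, read by MTT assay, with a stated time of 72 h; on this read-out lower numbers stand for stronger inhibition and higher numbers for weaker inhibition
Compound 2 `O=C(Nc1ccc(Cl)c(-c2nnc3c(Cl)cccn23)c1)c1ccccn1`: 75500 nM

Compound 1 reaches only a limit, (the limit of > 100000 nM in this assay, at which 1 of the 2 values shown sits). In this assay, within the data shown here, compound 2 gives 75500 nM, the sole number. Among the measured compounds shown here, the step of an at least 1.3-fold lower number from compound 1 to compound 2 (0.12 log units; that floor lies within the scatter) is the one measured comparison. Compound 3 `Cc1nc(C(=O)Nc2ccc(Cl)c(-c3nnc4c(Cl)cccn34)c2)cs1` carries 2-methyl-1,3-thiazol-4-yl in place of pyridin-2-yl on a carbonyl carbon. For the measured compounds named here, no measured step touches a five-membered ring on the carbonyl carbon, so the single measured step offers little guidance beyond indicating weak activity across the series. Compound 3 is therefore expected to stay weak, with a 1.1-fold lower number from compound 2 to compound 3 (0.03 log units; within the scatter) not beyond the scatter. The estimate for compound 3 is 70000 nM, ranging from 25000 nM to 200000 nM.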

Compound 3, half-maximal inhibitory concentration: 79800 nM
The estimate for compound 3 lay 1.1-fold (0.06 log units) below the measured number, within the range that was stated.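

In this assay the five-membered 2-methyl-1,3-thiazol-4-yl on a carbonyl carbon reads the same as the six-membered pyridin-2-yl, with a 1.1-fold higher number from compound 2 to compound 3 (0.02 log units; within the scatter), so this ring change separates nothing here. The step of an at least 1.2-fold lower number from compound 1 to compound 3 (0.09 log units; that floor lies within the scatter) also has a floor that does not clear the scatter. Compound 1 stands at a limit and not at a number: the limit of > 100000 nM in this assay, at which 1 of the 3 values shown sits.

As far as these compounds go, whether an amine or a carboxylic acid on the ring at this carbonyl carbon would give clearly stronger inhibition stays open. From the compounds shown here alone, how far the shared core itself holds the series in this weak range also stays open.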